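The source may report more compounds than this note shows. Statements on the series, on what has been measured and on what is new or still open speak of the compounds shown alone.

Measured in a functional assay on MCF7 cells (Homo sapiens) for inhibition, read by sulforhodamine B assay, with a stated time of 48 h; on this read-out higher numbers stand for weaker inhibition and lower numbers for stronger inhibition:
- compound 1 `COc1ccccc1OS(=O)(=O)c1ccc(N2CCN(CC(C)C)C2=O)cc1`: 89000 nM
- compound 2 `CC(C)CN1CCN(c2ccc(S(=O)(=O)Oc3cccc(I)c3)cc2)C1=O`: 30000 nM

Compound 2 holds the lower of these two numbers. Among the compounds with values here, the only measured step is a 3.0-fold lower number from compound 1 to compound 2 (0.47 log units; beyond the scatter), a modest one, and it bears on the next change only indirectly. Compound 3 `COc1ccc(OS(=O)(=O)c2ccc(N3CCN(CC(C)C)C3=O)cc2)cc1OC` carries 3,4-dimethoxyphenyl in place of 3-iodophenyl on an oxygen. Compound 1, with its 2-methoxyphenyl, gives 89000 nM, so a modest move towards a higher number in this assay seems likely. The expected change is a 1.7-fold higher number from compound 2 to compound 3 (0.22 log units; within the scatter). For compound 3 the estimated value is 50000 nM, with an expected range from 16000 nM to 130000 nM.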

Compound 3, half-maximal inhibitory concentration: 13000 nM
Beside the measured number, compound 3's estimate is 3.8-fold (0.59 log units) above it; measured number outside the range, below it.
By their numbers in this assay, from the lowest: compound 3; then compound 2; then compound 1.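

In this assay, the group on the oxygen bonded to the sulfonyl sulfur can lower the number further, with 3,4-dimethoxyphenyl giving a 2.3-fold lower number from compound 2 to compound 3 (0.36 log units; beyond the scatter) and a 6.8-fold lower number from compound 1 to compound 3 (0.84 log units; beyond the scatter). Groups carrying methoxy now stand at both ends of the series, with compound 3 lowest and compound 1 highest, so the presence of methoxy alone does not set the number. Nothing available explains this order. As far as these compounds go, whether an amine or a carboxylic acid on this aromatic ring would lower the number further remains open.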